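Series notes: from compound 3 to compound 4

The source may report more compounds than this note shows. Statements on the series, on what has been measured and on what is new or still open speak of the compounds shown alone.

For the measured compounds named here, compound 1 `COc1cccc(C(=O)Nc2ncc(Cc3cccc(C(F)(F)F)c3)s2)c1` is the only member of this set that comes with a number: in an assay on microsomes for inhibition of acyl-CoA desaturase 1 (Mus musculus), with a stated time of 60 min (on this read-out higher numbers stand for weaker inhibition and lower numbers for stronger inhibition), compound 1 gives 193 nM. Compound 2 `COc1ccc(C(=O)Nc2ncc(Cc3cccc(C(F)(F)F)c3)s2)cc1OCCCO` has no result; in this assay compound 2 is recorded as "not determined" (no result reported). Compound 3 `COc1ccc(C(=O)Nc2ncc(Cc3cccc(C(F)(F)F)c3)s2)cc1OCC(O)CO` is in the same position: in this assay compound 3 stands at "not determined" (no result reported). So compound 3 has no place on the numbers shown, and compound 2 shares that gap; the one anchor for the whole set is compound 1.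

Compound 4 `COc1ccc(C(=O)Nc2ncc(Cc3cccc(C(F)(F)F)c3)s2)cc1OCC(C)O` differs from compound 3 by hydrogen in place of hydroxy on a saturated chain carbon, two bonds along the chain from an oxygen on a saturated carbon, in words hydrogen in place of hydroxy on a saturated chain carbon, two bonds along the chain from an oxygen on a saturated carbon. Going by the values given here, no measured pair shows this step, so its size and direction are open. The working expectation is a step within the usual scatter of this assay relative to whatever compound 3 would give. With compound 3 unmeasured, the estimate rests on compound 1 at 193 nM as the nearest measured point. Compound 4 is expected to give about 150 nM in this assay, within a range from 40 nM to 600 nM.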

Compound 4, half-maximal inhibitory concentration: 2170 nM
The estimate for compound 4 lay 14-fold (1.16 log units) below the measured number; the measured number lies above the stated range.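

No new step can be read here: compound 3 has no number in this assay, so compound 4 at 2170 nM has no partner with a value that differs from it in one place. On these data alone, what the hydroxymethyl to methyl change does to inhibition stays open. Nothing shown bears on the cause of this result.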